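The compounds below may be only part of what the source reports. "The series", "measured", "known", "first", "only" and "open" are said of these compounds alone.

Three compounds share one core, and a fourth is about to be tested. In a functional assay on C6 cells (Rattus norvegicus) for cytotoxicity, read by MTT assay, with a stated time of 24 h (a lower number here means a stronger inhibitor, a higher number a weaker inhibitor), compound 1 `COc1ccc(-c2cs/c(=N/NC(=O)CSc3nncn3C)n2-c2ccccc2)cc1` is recorded as "not determined" (no result reported), so no number is in hand for it. In this assay compound 2 `COc1ccc(-c2cs/c(=N/NC(=O)CSc3ncccn3)n2-c2ccccc2)cc1` gives 102 ug/mL. In this assay compound 3 `COc1ccc(-c2cs/c(=N/NC(=O)CSc3nnc(C)s3)n2-c2ccccc2)cc1` gives 18.7 ug/mL, the lowest of the two numbers in hand; the step of a 5.5-fold lower number from compound 2 to compound 3 (0.74 log units; beyond the scatter) changes only the group on the sulfur. Compound 4 `Cc1ccc(-c2cs/c(=N/NC(=O)CSc3nnc(C)s3)n2-c2ccccc2)cc1` differs from compound 3 in another place: methyl in place of methoxy on an aromatic carbon. Going by the values given here, no measured step touches this ring; the single step from compound 2 to compound 3 concerns the group on the sulfur and so does not bear on a change of the group on the six-membered aromatic ring of carbon only. With nothing to point either way, a change no larger than the scatter is expected. Compound 4 is therefore estimated at 20 ug/mL in this assay, within a range from 8 ug/mL to 50 ug/mL. The expected step is a 1.1-fold higher number from compound 3 to compound 4 (0.03 log units; within the scatter), not beyond the scatter.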

Compound 4, half-maximal inhibitory concentration: 25.3 ug/mL
Estimate against measurement, compound 4: 1.3-fold (0.10 log units) below; the range from low to high includes it.
By their numbers in this assay, from the lowest: compounds 3 and 4 (each within the scatter of the next); then compound 2.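

In this assay, going by these compounds alone, putting methyl in place of methoxy on the six-membered aromatic ring gives a 1.4-fold higher number from compound 3 to compound 4 (0.13 log units; within the scatter) and so offers a first reading for a position away from the group on the sulfur. Taking away the oxygen, and with it the one hydrogen-bond acceptor counted for methoxy, leaves this pair within the scatter, whereas changing the group on the sulfur gave a 5.5-fold lower number from compound 2 to compound 3 (0.74 log units; beyond the scatter) beyond it. Nothing measured here offers an explanation for this result.

As far as these compounds go, whether an amine, a carboxylic acid or a longer chain on this same aromatic carbon would stay close to compound 3 and compound 4 remains open. From the compounds shown here alone, it is also open whether the change from 4-methoxyphenyl to 4-methylphenyl would read the same with pyrimidin-2-yl on the sulfur.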